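The source may report more compounds than this note shows. Statements on the series, on what has been measured and on what is new or still open speak of the compounds shown alone.

Working notes on the series. Of the compounds shown here, three of the shared core have been measured in a physicochemical assay for lipophilicity, read by HPLC, measured as octanol-water partition; a lower number here means a more polar compound, a higher number a more lipophilic compound. Compound 1 `CCN1CCN(C[C@H]2CN(c3ccc(-n4cc(-c5ccccn5)cn4)c(F)c3)C(=O)O2)CC1` gives 2.19. Compound 2 `O=C1O[C@@H](Cn2ccnn2)CN1c1ccc(-n2cc(-c3ccccn3)cn2)c(F)c1` gives 2. Compound 3 `NC(=O)[C@H]1CN(c2ccc(-n3cc(-c4ccccn4)cn3)c(F)c2)C(=O)O1` gives 1.59, the lowest of the three numbers; its nearest neighbour is compound 2, and the gap a number 0.41 log units lower from compound 2 to compound 3 (beyond the scatter) lies beyond the scatter, as does a number 0.60 log units lower from compound 1 to compound 3 (beyond the scatter). The step of a number 0.19 log units lower from compound 1 to compound 2 (within the scatter) stays within the scatter.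

Compound 4 `CONC(=O)[C@H]1CN(c2ccc(-n3cc(-c4ccccn4)cn3)c(F)c2)C(=O)O1` has not yet been measured in this assay. It differs from compound 3 by methoxy in place of hydrogen on an amide-type nitrogen. Within the data shown here, none of the measured steps bears directly on this change: each swaps the whole substituent on the saturated ring carbon, and the carbamoyl enters only in a number 0.60 log units lower from compound 1 to compound 3 (beyond the scatter) and a number 0.41 log units lower from compound 2 to compound 3 (beyond the scatter), both modest. Those steps say nothing about a methoxy on the amide-type nitrogen. A small rise is expected, near the edge of the scatter. The expected step is a number 0.26 log units higher from compound 3 to compound 4 (within the scatter). Compound 4 is therefore estimated at 1.85, with a range from 1.5 to 2.25.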

Compound 4, partition coefficient: >= 1.58
Compound 4: no number, only a limit; the forecaster's own chance of this, stated with the estimate: 0%; the middle value does not contradict the limit.
By their numbers in this assay, from the lowest: compound 3; then compounds 2 and 1 (each within the scatter of the next).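

In this assay compound 4 gives >= 1.58, which is a limit and not a number. Among these compounds, no step from compound 1, compound 2 or compound 3 to compound 4 can be read. The compounds shown leave open what methoxy in place of hydrogen on an amide-type nitrogen does to the partition coefficient.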